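Replacing 2-oxopyrrolidin-1-yl with phenyl on the shared core

The source may report more compounds than this note shows. Statements on the series, on what has been measured and on what is new or still open speak of the compounds shown alone.

Compound 1 `CNc1ccnc2c(O)c(-c3nc(C)n[nH]3)ncc12` gives > 250000 nM (a limit)
Compound 2 `Cc1n[nH]c(-c2ncc3c(N(C)C)ccnc3c2O)n1` gives > 250000 nM (a limit)
Compound 3 `Cc1n[nH]c(-c2ncc3c(N4CCCC4=O)ccnc3c2O)n1` gives 109000 nM (a number)

In a physicochemical assay for solubility, measured as kinetic solubility (a lower number here means a less soluble compound, a higher number a more soluble compound), compound 3 gives 109000 nM and is the only one of the three with a true number. Compound 1 and compound 2 both stand at the limit of > 250000 nM in this assay, at which 2 of the 3 values shown sit, and so have no exact value. Compound 3 therefore has the lowest number shown.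

The next compound, compound 4 `Cc1n[nH]c(-c2ncc3c(-c4ccccc4)ccnc3c2O)n1`, has phenyl in place of 2-oxopyrrolidin-1-yl on an aromatic carbon, opposite the ring nitrogen: phenyl in place of 2-oxopyrrolidin-1-yl on an aromatic carbon.

Two measured steps change the group at this carbon: an at least 2.2-fold lower number from compound 1 to compound 3 (0.36 log units; beyond the scatter) and an at least 2.2-fold lower number from compound 2 to compound 3 (0.36 log units; beyond the scatter). Each is bounded on one side only, so it gives a minimum size and not a true one. For the measured compounds named here, no measured compound carries phenyl, so neither step can be carried over directly. Even so, both show that this assay responds to a change of group here. A moderate further step to a lower number is expected, though a result close to compound 3 remains possible.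

The estimated step is a 2.7-fold lower number from compound 3 to compound 4 (0.44 log units; beyond the scatter). For compound 4 the expected value is 40000 nM, with an estimated range from 10000 nM to 150000 nM.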

Compound 4, solubility: 160000 nM
The estimate for compound 4 lay 4.0-fold (0.60 log units) below the measured number; the whole stated range lies below it.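

In this assay, phenyl in place of 2-oxopyrrolidin-1-yl on this aromatic carbon, opposite the ring nitrogen, gives a 1.5-fold higher number from compound 3 to compound 4 (0.17 log units; within the scatter). For the compounds shown here, this shows that the assay does not separate these two groups here, although one is a six-membered aromatic ring of carbon only and the other a five-membered non-aromatic ring with a hydrogen-bond acceptor, so the earlier steps to compound 3 did not mean that any change of group at this carbon would lower the number further. Phenyl in place of dimethylamino gives an at least 1.5-fold lower number from compound 2 to compound 4 (0.19 log units; that floor lies within the scatter), and phenyl in place of methylamino gives an at least 1.5-fold lower number from compound 1 to compound 4 (0.19 log units; that floor lies within the scatter), so neither floor alone sets compound 4 apart from the two amino compounds, and their true sizes stay unknown because both compounds stand at a limit: the limit of > 250000 nM in this assay, at which 2 of the 4 values shown sit.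

The compounds shown leave open whether a pyridyl ring at this carbon, or a phenyl carrying a carboxylic acid or an amine, would stay within the scatter of compound 4 or move clearly away from it. They also leave open whether a longer chain on the amino nitrogen would keep the number at the limit seen for compound 1 and compound 2.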